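Triazine series: fluoro to methoxy on the aryl ring

This account rests on a few compounds, and the source may have more. Where it says the series, first, only, none or still open, it means among the compounds named here.

Three compounds with a shared core carry a hydroxymethyl group on a six-membered aromatic ring of carbon only and have been measured in a functional assay on cells for positive allosteric modulation of G-protein coupled receptor 68 (Homo sapiens), read by a luciferase reporter and cAMP accumulation, with a stated time of 30 min, at pH 6.8 and pH 8.3, in the presence of a further agent that is not named here; a lower number here means a less potent compound, a higher number a more potent compound, by a factor of ten per unit of this negative logarithm. Compound 1, `CNc1nc(NCc2ccccc2)nc(-c2ccccc2CO)n1`, gives 4.51. Compound 3, `COc1ccc(-c2nc(N)nc(NCc3ccccc3)n2)c(CO)c1`, which also bears a methoxy group on that ring, gives 4.12. Compound 2, `Nc1nc(NCc2ccccc2)nc(-c2c(F)cccc2CO)n1`, gives 3.69 and stands lowest of the three: compound 3 is nearest, higher by a margin beyond the scatter, and compound 1 is furthest, also beyond the scatter.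

The unmeasured compound 4, `COc1cccc(CO)c1-c1nc(N)nc(NCc2ccccc2)n1`, is compared with compound 2. The change is methoxy in place of fluoro on an aromatic carbon. Among the measured compounds shown here, no pair of measured compounds differs in one place only, so no measured step sets the size of this change directly. For the measured compounds named here, the only guide is that compound 3, which carries a methoxy group on the same ring, sits higher than compound 2 in this assay.

On that basis compound 4 is expected to land near or somewhat above compound 2, with the estimated step of a number 0.31 log units higher from compound 2 to compound 4 (beyond the scatter) small and close to the edge of the scatter. Compound 4 is estimated at 4 in this assay, with a range from 3.5 to 4.6.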

Compound 4, negative logarithm of the antagonist equilibrium constant: "not active" (no number reported)
Compound 4 has no reported number here, so the estimate cannot be set against anything.
By their numbers in this assay, from the lowest: compound 2; then compound 3; then compound 1.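

In this assay, among the compounds shown here, compound 4 is reported as not active, without a number, so no step from compound 2 to compound 4 can be read. The compounds shown leave open how methoxy in place of fluoro at this place shifts potency on a numerical scale. No available evidence bears on this result.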